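Thiosemicarbazone to benzyl isothiosemicarbazone on a shared core

The compounds below may be only part of what the source reports. "The series", "measured", "known", "first", "only" and "open" are said of these compounds alone.

Of the compounds shown here, three of one core have been tested in a functional assay on Bel-7402 cells (Homo sapiens) for antiproliferative activity, read by MTT assay, with a stated time of 72 h; on this read-out lower numbers stand for stronger inhibition and higher numbers for weaker inhibition. Compound 1, `Cc1cccc(NC2=C/C(=N/NC(N)=S)C(=O)N=C2Nc2cccc(C)c2)c1`, gives 2730 nM, the lowest of the three numbers. Compound 2, `NC(=S)N/N=C1/C=C(Nc2ccccc2Cl)C(Nc2ccccc2Cl)=NC1=O`, gives 3420 nM, which lies within the scatter of compound 1, so no order between the two can be claimed. Compound 3, `COc1ccc(NC2=C/C(=N/NC(N)=S)C(=O)N=C2Nc2ccc(OC)cc2)cc1`, gives 17800 nM, a gap to compound 1 that lies beyond the scatter.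

Compound 4, `Cc1cccc(NC2=C/C(=N/N=C(\N)SCc3ccccc3)C(=O)N=C2Nc2cccc(C)c2)c1`, differs from compound 1 in one place: a group of 11 heavy atoms (8 carbon, 2 nitrogen, 1 sulfur; one six-membered aromatic ring of carbon only) in place of a group of 4 heavy atoms (1 carbon, 2 nitrogen, 1 sulfur; no ring), on a double-bonded nitrogen. The new group keeps one hydrogen-bond donor and brings in a six-membered aromatic ring of carbon only. Among the measured compounds shown here, no pair of measured compounds shows what such a change does on this core, so nothing beyond the scatter can be assumed in either direction.

The step of a 1.3-fold higher number from compound 1 to compound 4 (0.11 log units; within the scatter) is therefore expected to stay within the scatter. For compound 4 the expected value in this assay is 3500 nM, with a range from 1000 nM to 12000 nM.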

Compound 4, half-maximal inhibitory concentration: 8720 nM
Estimate against measurement, compound 4: 2.5-fold (0.40 log units) below; measured number inside the range.
By their numbers in this assay, from the lowest: compounds 1 and 2 (each within the scatter of the next); then compound 4; then compound 3.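

In this assay, the change on the double-bonded nitrogen gives a 3.2-fold higher number from compound 1 to compound 4 (0.50 log units; beyond the scatter), a modest step. Among the compounds shown here, the earlier compounds all carry the group of 4 heavy atoms at this place, so they could not show that this position responds to a change; this step is the first reading of it. The group of 11 heavy atoms, with its six-membered aromatic ring of carbon only, weakens inhibition on this core without removing it, and nothing shown gives a reason for that step.

The compounds shown leave open whether the same change would give a similar step with the chloro or methoxy groups of compound 2 and compound 3. They also leave open whether a small methyl group or a basic morpholine-bearing chain in place of the benzyl group would give a different number.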